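This account rests on a few compounds, and the source may have more. Where it says the series, first, only, none or still open, it means among the compounds named here.

Working notes on the series, cytotoxicity read-out.

Compound 2 `Fc1ccc(/C=N/c2sc3c(c2-c2nc4ccccc4s2)CCCC3)cc1` and compound 1 `Clc1ccccc1/C=N/c1sc2c(c1-c1nc3ccccc3s1)CCC2` share a core and differ in more than one place, so their values are set side by side without a step. In an ADME assay on HeLa cells (Homo sapiens) for cytotoxicity, read by MTT assay, with a stated time of 72 h (on this read-out lower numbers stand for higher toxicity in this test and higher numbers for lower toxicity in this test), compound 2 gives 277 ug/mL. In this assay compound 1 gives 138 ug/mL; the two numbers lie within the usual scatter of each other, so no order is read from them.

Compound 3 `Fc1ccccc1/C=N/c1sc2c(c1-c1nc3ccccc3s1)CCCC2` is not yet measured in this assay. It differs from compound 2 by 2-fluorophenyl in place of 4-fluorophenyl on a carbon with a double bond to nitrogen. Within the data shown here, no measured pair shows this change alone. With both measured compounds giving numbers in the same region, a step from compound 2 to compound 3 of no more than the scatter is expected, in either direction; the expected step is a 1.4-fold lower number from compound 2 to compound 3 (0.14 log units; within the scatter). In this assay compound 3 is estimated at 200 ug/mL, with a range from 90 ug/mL to 450 ug/mL.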

Compound 3, half-maximal cytotoxic concentration: 426 ug/mL
The estimate for compound 3 lay 2.1-fold (0.33 log units) below the measured number; measured number inside the range.
By their numbers in this assay, from the lowest: compounds 1, 2 and 3 (each within the scatter of the next, the first and the last beyond it).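

Among these compounds, compound 2 and compound 3 give the first single-change reading at this position: in this assay, 2-fluorophenyl in place of 4-fluorophenyl on a carbon with a double bond to nitrogen gives a 1.5-fold higher number from compound 2 to compound 3 (0.19 log units; within the scatter). No order is read between the two, so within this pair, the exchange of one fluorophenyl group for the other does not separate the read-out beyond the scatter. No measured property bears on this result, and the data offer no explanation of it.

Compound 1 differs from each of the others in more than one place, so the separate contributions of its differences remain unresolved. Going by these compounds, whether an amine, a carboxylic acid or a longer chain on the phenyl ring at this position would give a step beyond the scatter also remains open.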